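The compounds below may be only part of what the source reports. "The series", "measured", "known", "first", "only" and "open" are said of these compounds alone.

Working notes on the series in a toxicity assay on THP-1 cells (Homo sapiens) for inhibition; on this read-out lower numbers stand for higher toxicity in this test and higher numbers for lower toxicity in this test. Three members carry a reading so far. Compound 1 `COc1ccccc1-c1cnc(NC(=O)c2ccc(F)cc2)n1C` gives only a limit and not a number, > 100000 nM. Compound 2 `Cn1c(-c2ccccc2F)cnc1NC(=O)c1ccc(F)cc1` likewise gives a limit rather than a number, > 100000 nM. Within the data shown here, compound 3 `Cc1ccc(-c2cnc(NC(=O)c3ccc(F)cc3)n2C)cc1` is the sole member with a measured number, 60000 nM in this assay, so it stands alone as the only fixed point. The comparison from compound 1 to compound 3 reads an at least 1.6-fold lower number from compound 1 to compound 3 (0.22 log units; that floor lies within the scatter), and from compound 2 to compound 3 it reads an at least 1.6-fold lower number from compound 2 to compound 3 (0.22 log units; that floor lies within the scatter); both are open-ended because two of the three values sit at the limit of > 100000 nM in this assay, at which 2 of the 3 values shown sit. The step from compound 1 to compound 2, a step that the two limits leave unreadable from compound 1 to compound 2, cannot be read at all.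

Compound 4 `Cn1c(-c2ccccc2)cnc1NC(=O)c1ccc(F)cc1` is the next candidate; it differs from compound 3 by hydrogen in place of methyl on an aromatic carbon. Among the measured compounds shown here, no measured step matches this change: the two readable steps each swap one whole aryl group for another, whereas here only hydrogen in place of methyl on an aromatic carbon is involved. With no guide of that kind, no step beyond the scatter is expected for compound 4 in this assay, meaning an expected step of a 1.3-fold higher number from compound 3 to compound 4 (0.10 log units; within the scatter). Compound 4 is therefore estimated at 75000 nM, with a likely range from 25000 nM to 200000 nM.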

Compound 4, half-maximal cytotoxic concentration: > 100000 nM
Compound 4 ended at the assay's limit; the forecaster's own chance of this, stated with the estimate: 40%; at least 1.3-fold (0.12 log units) between middle value and limit.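

Hydrogen in place of methyl on an aromatic carbon, para to a large group, gives an at least 1.6-fold higher number from compound 3 to compound 4 (0.22 log units; that floor lies within the scatter) in this assay. Among these compounds, this is the first reading of a change at this single position, whereas the earlier readable steps swapped one whole aryl group for another, and its floor does not establish a step beyond the scatter, so the true size stays open. Compound 3 remains the only member with a measured number, and the steps among compound 1, compound 2 and compound 4 cannot be read, because all three carry limits rather than numbers: the limit of > 100000 nM in this assay, at which 3 of the 4 values shown sit.

Open, going by these compounds, is whether an ethyl, a chloro, an amine or a carboxylic acid on this same aromatic carbon would give a measured number, as the methyl of compound 3 does, or a limit, as the hydrogen of compound 4 does. Equally open, on these data alone, is whether a replacement elsewhere on the shared core would shift the reading of compound 3.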